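A few compounds are considered here, and "the series" means these few. Any claim that something is new, unique, unknown or untested is made for them only; others in the source may bear on it.

Of the compounds shown here, two built on one shared core have been tested in a functional assay on HeLa cells (Homo sapiens) for inhibition, read by MTT assay, with a stated time of 48 h; a higher number here means a weaker inhibitor, a lower number a stronger inhibitor. Compound 1 `CCOC(=O)C1=C(N/C=N/c2ncc(-c3ccccc3)s2)Nc2[nH]nc(C)c2C1c1ccc(N(C)C)cc1` gives 15400 nM, the higher of the two numbers, so it is the weaker inhibitor of the pair. Compound 2 `CCOC(=O)C1=C(N)Nc2[nH]nc(C)c2C1c1ccc(N(C)C)cc1` gives 6220 nM, a lower number that lies beyond the scatter of the measurement. Compound 3 `CCOC(=O)C1=C(N/C=N/c2ccc([N+](=O)[O-])cc2)Nc2[nH]nc(C)c2C1c1ccc(N(C)C)cc1` has not yet been measured; it differs from compound 1 by 4-nitrophenyl in place of 5-phenyl-1,3-thiazol-2-yl on a double-bonded nitrogen. Among the compounds with values here, no pair of measured compounds shows what such a swap does here, so the expectation rests on compound 1 alone. The step from compound 1 to compound 3 is expected to be small, in the order of a 1.2-fold lower number from compound 1 to compound 3 (0.07 log units; within the scatter), with no clear direction and likely none beyond the scatter. Compound 3 is therefore expected to give about 13000 nM in this assay , with a range from 4000 nM to 45000 nM.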

Compound 3, half-maximal inhibitory concentration: 57800 nM
Beside the measured number, compound 3's estimate is 4.4-fold (0.65 log units) below it; the whole stated range lies below it.
By their numbers in this assay, from the lowest: compound 2; then compound 1; then compound 3.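

In this assay, the group on the double-bonded nitrogen turns out to matter: 4-nitrophenyl in place of 5-phenyl-1,3-thiazol-2-yl gives a 3.8-fold higher number from compound 1 to compound 3 (0.57 log units; beyond the scatter) and so makes a weaker inhibitor, which shows that these two aromatic groups are not interchangeable here. Measured against the plain amine, the larger group bearing 4-nitrophenyl gives a 9.3-fold higher number from compound 2 to compound 3 (0.97 log units; beyond the scatter) and compound 1, at 15400 nM, also stands above compound 2, at 6220 nM, so both substituted compounds shown are weaker than the unsubstituted amine. Nothing available explains why the numbers shift in this way.

The compounds shown leave open how a plain phenyl or a 4-aminophenyl group would behave at this place. They also leave open whether any group on this nitrogen can give a lower number than compound 2 does.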